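Trifluoromethyl in place of cyano on the anilide

This account rests on a few compounds, and the source may have more. Where it says the series, first, only, none or still open, it means among the compounds named here.

Compound 1 `COc1ccc(NC(=O)c2csc(Cc3c(Cl)cccc3Cl)n2)cc1` gives > 4000 nM in an assay on CHO cells, read by calcium flux (a higher number here means a weaker inhibitor, a lower number a stronger inhibitor), a limit of the assay. Compound 2 `N#Cc1ccc(NC(=O)c2csc(Cc3c(Cl)cccc3Cl)n2)cc1` gives 720 nM in this assay.

Compound 2 holds the only number shown; the other value is a limit. Going by the values given here, the single measured step, an at least 5.5-fold lower number from compound 1 to compound 2 (0.74 log units; beyond the scatter), is the only guide, and its size is bounded by the limit of > 4000 nM in this assay, at which 1 of the 2 values shown sits. Compound 3 `O=C(Nc1ccc(C(F)(F)F)cc1)c1csc(Cc2c(Cl)cccc2Cl)n1` differs from compound 2 by trifluoromethyl in place of cyano on an aromatic carbon. Among the compounds with values here, no measured step exchanges one such group for another, so the change from cyano to trifluoromethyl is expected to move this assay little: a 1.3-fold higher number from compound 2 to compound 3 (0.10 log units; within the scatter) is expected to stay within the scatter. Compound 3 is estimated at 900 nM, between 300 nM and 3000 nM.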

Compound 3, half-maximal inhibitory concentration: 88 nM
Compound 3: the middle estimate sits 10-fold (1.01 log units) above what was measured; the measured number lies below the stated range.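

In this assay trifluoromethyl in place of cyano gives an 8.2-fold lower number from compound 2 to compound 3 (0.91 log units; beyond the scatter) at this position, so the aromatic carbon para to a large group responds to more than the change away from methoxy. Against methoxy, trifluoromethyl gives an at least 45-fold lower number from compound 1 to compound 3 (1.65 log units; beyond the scatter) on the same carbon. The value of compound 1 is a limit of the assay, so that step is only a bound: the limit of > 4000 nM in this assay, at which 1 of the 3 values shown sits.

Going by these compounds, how this position responds to other groups, such as an amine, a carboxylic acid or a longer chain, stays open. On these data alone, whether the same exchange holds on a changed core also stays open.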